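A few compounds are considered here, and "the series" means these few. Any claim that something is new, unique, unknown or untested is made for them only; others in the source may bear on it.

Compound 1 `COc1cccc(-c2nc(NN)n(C)c(=O)c2C#N)c1OC` gives 44 ug/mL in a functional assay, with a stated time of 20 min; a higher number here means a weaker inhibitor, a lower number a stronger inhibitor. Compound 2 `COc1cccc(-c2nc(SC)n(C)c(=O)c2C#N)c1OC` gives 54 ug/mL in this assay; the structural change is methylsulfanyl in place of aminoamino on an aromatic carbon and the resulting step is a 1.2-fold higher number from compound 1 to compound 2 (0.09 log units; within the scatter). Compound 3 `Cn1c(NN)nc(-c2ccccc2Cl)c(C#N)c1=O` gives 58 ug/mL in this assay; its core is not that of compound 1, and the difference between the two cores is not broken down here. The values of compound 1, compound 2 and compound 3 all lie within the scatter of one another, so no order among them is claimed.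

Compound 4 `CSc1nc(-c2ccccc2Cl)c(C#N)c(=O)n1C` is not yet measured. It differs from compound 3 by methylsulfanyl in place of aminoamino on an aromatic carbon. Among the compounds with values here, this is the same kind of change as the one from compound 1 to compound 2; the surroundings differ only in that the place is described as meta to a group of 7 heavy atoms in one case and meta to a large group in the other. For compound 4 the step of a 1.2-fold higher number from compound 3 to compound 4 (0.07 log units; within the scatter) is expected to echo the earlier one, because a 1.2-fold higher number from compound 1 to compound 2 (0.09 log units; within the scatter) shows the same change on the other core staying within the scatter. The estimate for compound 4 in this assay is 68 ug/mL, between 35 ug/mL and 135 ug/mL.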

Compound 4, half-maximal inhibitory concentration: 76 ug/mL
Compound 4: the middle estimate sits 1.1-fold (0.05 log units) below what was measured, within the range that was stated.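

In this assay, methylsulfanyl in place of aminoamino on an aromatic carbon gives a 1.3-fold higher number from compound 3 to compound 4 (0.12 log units; within the scatter), and this step agrees with the earlier one on the other core: the same change on two cores in this assay, a 1.2-fold higher number (0.09 log units; within the scatter) from compound 1 to compound 2 and a 1.3-fold higher number (0.12 log units; within the scatter) from compound 3 to compound 4, 1.1-fold (0.03 log units) apart, within the scatter of two such steps On both cores the step stays within the scatter, which means the change carries from the core of compound 1 to the core of compound 3 without a detectable difference in this read-out. Within the data shown here, this rests on only two matched pairs: it sets no direction for the change, and it does not show that the two groups are interchangeable on any other core or in any other measurement.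

From the compounds shown here alone, whether any group at this carbon can move the number beyond the scatter remains open, for example a simple amine, a methoxy group or a longer chain such as butylsulfanyl. Also open, going by these compounds, is whether the same change would hold up with a carboxylic acid in place of the cyano group.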